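The source may hold more compounds than are shown below. What is called first, only, known or untested is meant among the compounds shown, and "the series" means these compounds.

Three compounds have been measured in a functional assay on MDA-MB-231 cells (Homo sapiens) for inhibition, read by sulforhodamine B assay, with a stated time of 48 h; on this read-out lower numbers stand for stronger inhibition of growth and higher numbers for weaker inhibition of growth:

Compound 1, `O=C(N/N=C/C1=C(Cl)c2ccccc2CCC1)c1ccccc1`, gives 11100 nM.
Compound 2, `Cc1ccc(C(=O)N/N=C/C2=C(Cl)c3ccccc3CCC2)cc1`, gives 710 nM.
Compound 3, `Cc1cc2c(cc1C)C(Cl)=C(/C=N/NC(=O)c1ccccc1)CCC2`, gives 2500 nM.

Compound 2 differs from compound 1 by methyl in place of hydrogen on an aromatic carbon. That single change produced a 16-fold lower number from compound 1 to compound 2 (1.19 log units; beyond the scatter). Compound 3 carries a different core from compound 1; the difference between the two cores is not broken down here.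

Compound 4, `Cc1ccc(C(=O)N/N=C/C2=C(Cl)c3cc(C)c(C)cc3CCC2)cc1`, has not yet been measured. It differs from compound 3 by methyl in place of hydrogen on an aromatic carbon, the same change, at the same kind of place, that turned compound 1 into compound 2.

In this assay the expected step is a 7.1-fold lower number from compound 3 to compound 4 (0.85 log units; beyond the scatter), taken a little smaller than the earlier one because a 16-fold lower number from compound 1 to compound 2 (1.19 log units; beyond the scatter) was seen on a different core and a single example is a thin basis. Compound 4 is therefore estimated at 350 nM, expected to lie between 120 nM and 1200 nM.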

Compound 4, concentration for 50% growth inhibition: 32900 nM
Compound 4: middle estimate off by 94-fold (1.97 log units), on the low side; measured number outside the range, above it.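

In this assay the change from phenyl to 4-methylphenyl gave a 13-fold higher number from compound 3 to compound 4 (1.12 log units; beyond the scatter) and so ran opposite to what the same change did on the core of compound 1. Within the data shown here, with only two pairs, this does not show what in the cores decides the outcome, or how the change would behave on a further core. What it does show is that, in this series, neither the size nor the direction of this step carried from one core to the other: the same change on two cores in this assay, a 16-fold lower number (1.19 log units; beyond the scatter) from compound 1 to compound 2 and a 13-fold higher number (1.12 log units; beyond the scatter) from compound 3 to compound 4, 210-fold (2.31 log units) apart, beyond the scatter of two such steps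

The compounds shown leave open whether another group at this place, such as a methoxy group, a chlorine atom or an amine, would also pull the two cores in opposite directions. They also leave open whether a longer chain would do the same.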